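Hydroxy for methyl on the chain of compound 3

This account rests on a few compounds, and the source may have more. Where it says the series, first, only, none or still open, it means among the compounds named here.

Measured so far in a functional assay on Raji cells (Homo sapiens) for antiproliferative activity, read by MTT assay, with a stated time of 48 h (a lower number here means a stronger inhibitor, a higher number a weaker inhibitor), are three compounds:
- Compound 1 (`Cn1c(N)c(-c2nc3ccccc3[nH]2)c2nc(C#N)c(C#N)nc21`) gives > 50000 nM as a limit.
- Compound 2 (`CCN(CC)CCn1c(N)c(-c2nc3ccccc3[nH]2)c2nc(C#N)c(C#N)nc21`) gives 8950 nM as a number.
- Compound 3 (`CCCCn1c(N)c(-c2nc3ccccc3[nH]2)c2nc(C#N)c(C#N)nc21`) gives > 50000 nM as a limit.

Compound 3 sits at the limit of > 50000 nM in this assay, at which 2 of the 3 values shown sit, and so has no number of its own. Compound 4 (`N#Cc1nc2c(-c3nc4ccccc4[nH]3)c(N)n(CCCO)c2nc1C#N`) has hydroxy in place of methyl on a saturated chain carbon, three bonds along the chain from an aromatic nitrogen. Within the data shown here, two measured steps bear on this change, an at least 5.5-fold higher number from compound 2 to compound 3 (0.74 log units; beyond the scatter) for ethyl in place of diethylamino and a step that the two limits leave unreadable from compound 1 to compound 3 for propyl in place of hydrogen. Among the measured compounds shown here, no measured compound carries hydroxy. The step expected in this assay is therefore small, toward a lower number if it can be read at all, and is estimated as an at least 1.4-fold lower number from compound 3 to compound 4 (0.15 log units; that floor lies within the scatter) in size. The estimate for compound 4 is 35000 nM with an expected range from 10000 nM to 50000 nM overall.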

Compound 4, half-maximal inhibitory concentration: > 50000 nM
Compound 4 gave a limit, no number; the forecaster's own chance of this, stated with the estimate: 55%; middle value at least 1.4-fold (0.15 log units) away from the limit.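

In this assay compound 4 gives > 50000 nM, which is a limit and not a number, so a hydroxy on the chain does not bring a measurable value. The steps to compound 4 from compound 3 and from compound 1 cannot be read, since both ends of each are limits: the limit of > 50000 nM in this assay, at which 3 of the 4 values shown sit. Hydroxymethyl in place of diethylamino gives an at least 5.5-fold higher number from compound 2 to compound 4 (0.74 log units; beyond the scatter), so the hydroxy-ended chain does not match the chain of compound 2.

On these data alone, whether another amine, such as morpholine or pyrrolidine, at the chain end would give a value like that of compound 2 stays open. So does the effect of a longer chain carrying diethylamino.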